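The source may report more compounds than this note shows. Statements on the series, on what has been measured and on what is new or still open speak of the compounds shown alone.

Measured so far in an ADME assay on a cell-free system (plasma, Homo sapiens) for metabolic stability, with Plasma (Rattus norvegicus) as the target, read by HPLC, at pH 7.4; on this read-out higher numbers stand for a longer-lived compound and lower numbers for a shorter-lived compound:

- compound 1 `CC(=O)Oc1ccccc1C(=O)O[C@H]1CO[C@H]2[C@@H]1OC[C@H]2OC(=O)c1ccnn1C`: 0.0963 h
- compound 2 `CC(=O)Oc1ccccc1C(=O)O[C@H]1CO[C@H]2[C@@H]1OC[C@H]2OC(=O)c1ccc(-c2ccccc2)cc1`: > 0.333 h

Compound 2 stands at the upper edge of what has been read, but its number is only a limit of this assay and not a measured value; this is the limit of > 0.333 h in this assay, at which 1 of the 2 values shown sits. For the measured compounds named here, compound 1 is the single compound with a proper number, and the one step measured, an at least 3.4-fold higher number from compound 1 to compound 2 (0.53 log units; beyond the scatter), is the only guide to how the ester group on the carbonyl carbon moves the half-life.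

Compound 3 `CC(=O)Oc1ccccc1C(=O)O[C@H]1CO[C@H]2[C@@H]1OC[C@H]2OC(=O)c1ccccc1CO[N+](=O)[O-]` differs from compound 2 by 2-((nitrooxy)methyl)phenyl in place of 4-phenylphenyl on a carbonyl carbon. Going by the values given here, no measured step covers this exchange, and the one step known, an at least 3.4-fold higher number from compound 1 to compound 2 (0.53 log units; beyond the scatter), compares a five-membered heteroaromatic ester with the biphenyl ester rather than two carbocyclic benzoates. Since compound 2 only gives a limit, the starting point itself is uncertain. The expectation is a modest move downward, an at least 1.3-fold lower number from compound 2 to compound 3 (0.12 log units; that floor lies within the scatter), with wide bounds on either side. Compound 3 is therefore estimated at 0.25 h, within 0.08 h to 0.9 h, and it may again return only a limit.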

Compound 3, half-life: 0.045 h
Compound 3: middle estimate off by 5.6-fold (0.74 log units), on the high side, and the stated range ends above it.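

In this assay, 2-((nitrooxy)methyl)phenyl in place of 4-phenylphenyl on the carbonyl carbon gives an at least 7.4-fold lower number from compound 2 to compound 3 (0.86 log units; beyond the scatter), so the earlier pair's gap between a heteroaromatic ester and a biphenyl ester is now joined by a clear gap between two esters built on benzene rings. The same group also compares unfavourably with 1-methyl-1H-pyrazol-5-yl, with a 2.1-fold lower number from compound 1 to compound 3 (0.33 log units; beyond the scatter), which makes compound 3 the shortest-lived of the three compounds and shows that this position can shorten the half-life as well as lengthen it. The first of these steps has no upper end, since compound 2 carries only a limit and not a measured value: the limit of > 0.333 h in this assay, at which 1 of the 3 values shown sits.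

The compounds shown leave open whether the drop belongs to the nitrooxy group or to any group on the ring at that place, which a plain phenyl ester or a 2-(hydroxymethyl)phenyl ester would help to separate. They also leave open which of the ester groups in the molecule is lost first, and how long compound 2 actually lasts.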